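Sulfonyl chain lengthening across two cores: cytotoxicity notes

A few compounds are considered here, and "the series" means these few. Any claim that something is new, unique, unknown or untested is made for them only; others in the source may bear on it.

Three compounds are measured in a functional assay on Huh-7 cells (Homo sapiens) for cytotoxicity, read by MTT assay, with a stated time of 72 h; a higher number here means that more compound is tolerated, a lower number that less compound is tolerated. Compound 1 `CCCS(=O)(=O)N1CCC2(CC1)OOC1(CCCCC1)OO2` carries a propyl chain on the sulfonyl sulfur. In this assay compound 1 gives > 100 ug/mL, which is a limit of the assay and not a number. Compound 2 `CCCS(=O)(=O)N1CCC2(CC1)OOC1(CCCCCC1)OO2` keeps the propyl chain on a different core; the difference between the two cores is not broken down here. In this assay compound 2 gives > 100 ug/mL, likewise a limit. Compound 3 `CCCCS(=O)(=O)N1CCC2(CC1)OOC1(CCCCC1)OO2` is compound 1 with methyl in place of hydrogen on a saturated chain carbon, three bonds along the chain from a sulfonyl sulfur. In this assay compound 3 gives > 100 ug/mL, again a limit. In this assay the resulting step is a step that the two limits leave unreadable from compound 1 to compound 3; both ends sit at the limit of > 100 ug/mL in this assay, at which 3 of the 3 values shown sit, so its size cannot be read from the data.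

Compound 4 `CCCCS(=O)(=O)N1CCC2(CC1)OOC1(CCCCCC1)OO2`, not yet measured, is compound 2 with methyl in place of hydrogen on a saturated chain carbon, three bonds along the chain from a sulfonyl sulfur, the same change in the same place as that made on compound 1. Going by the values given here, every measured value in the set sits at the limit of > 100 ug/mL in this assay, at which 3 of the 3 values shown sit, so there is no numerical step to carry over, only the observation that the change left compound 3 at the limit and that compound 2 already stands there. In this assay the step is expected to be a step that the limit leaves unreadable from compound 2 to compound 4, again not readable. Compound 4 is expected to give about 120 ug/mL, most probably reported as a limit rather than a number. The expected range for compound 4 runs from 60 ug/mL to 300 ug/mL.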

Compound 4, half-maximal cytotoxic concentration: > 100 ug/mL
Compound 4 ended at the assay's limit; the forecaster's own chance of this, stated with the estimate: 90%; the middle value lies beyond the limit too.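

In this assay compound 4 gives > 100 ug/mL as a limit of the assay and not a number. No size can be read for the change from compound 2 to compound 4, or for the same change from compound 1 to compound 3, because all the values are limits: the limit of > 100 ug/mL in this assay, at which 4 of the 4 values shown sit.

The compounds shown leave open whether propyl to butyl shifts the half-maximal cytotoxic concentration at all on either core.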